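Swapping a Pyridin-2-yl for a 3-Methylphenyl Group

A few compounds are considered here, and "the series" means these few. Any claim that something is new, unique, unknown or untested is made for them only; others in the source may bear on it.

Of the compounds shown here, two have been measured in an assay on CHO cells for displacement of a labelled ligand from adenosine receptor A3 (Homo sapiens), read by scintillation counting, tested at 10 uM; a lower number here means less inhibition, a higher number more inhibition at the concentration tested (going by the name of the read-out). Compound 1 `CC(C)Cc1csc(N)c1C(=O)c1ccc(Cl)cc1` gives 1% in this assay, so it barely displaces the labelled ligand at the concentration tested. Compound 2 `CC(C)(C)Cc1c(-c2ccccn2)sc(N)c1C(=O)c1ccc(Cl)cc1` carries a pyridin-2-yl group and a neopentyl group on the shared core, and in this assay compound 2 gives 1%. Compound 2 therefore stands level with compound 1 at the digits shown; the two values lie within the usual scatter of repeated measurements of this kind, so no difference between them can be claimed.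

Compound 3 `Cc1cccc(-c2sc(N)c(C(=O)c3ccc(Cl)cc3)c2CC(C)(C)C)c1` has not yet been measured. Compared with compound 2 it differs in a single place: 3-methylphenyl in place of pyridin-2-yl on an aromatic carbon. Among the measured compounds shown here, no step between two measured compounds is available to guide this change, since the only two compounds measured do not differ in one place. Both sit at the bottom of the scale, so the step of a number 2 percentage points higher from compound 2 to compound 3 (within the scatter) is expected to be none beyond the scatter. Compound 3 is estimated to give 3% in this assay, with a range from -8% to 15%.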

Compound 3, a percentage reported as inhibition, at one concentration (the size of the read-out at that concentration, not a potency): 1%
Estimate against measurement, compound 3: 2 percentage points above; the measured number falls inside the stated range.
By their numbers in this assay, from the lowest: compounds 1, 2 and 3 (each within the scatter of the next).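

Among the compounds shown here, compound 2 and compound 3 are the first pair here that differ in one place, so this position can now be read directly. In this assay, putting 3-methylphenyl in place of pyridin-2-yl on the aromatic carbon next to the ring sulfur gives no change at the digits printed from compound 2 to compound 3 (within the scatter). This exchange removes the ring nitrogen and the hydrogen-bond acceptor counted for pyridin-2-yl and brings in a ring of carbon only with a methyl group, yet the read-out does not register the swap, and nothing available offers an explanation for that.

All three compounds sit at the bottom of the scale, so a group at this position could matter in a compound showing more inhibition and still leave no trace here. Whether an amine or a carboxylic acid on the aromatic carbon next to the ring sulfur, or a longer chain in place of the neopentyl group, would lift the inhibition at all remains an open question.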